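A Thiazolyl Group on the Amino Nitrogen

The compounds below may be only part of what the source reports. "The series", "measured", "known", "first", "only" and "open" are said of these compounds alone.

In a functional assay on GOTO cells (Homo sapiens) for cytotoxicity, read by MTT assay, with a stated time of 3 days (a lower number here means a stronger inhibitor, a higher number a weaker inhibitor), compound 1 `N#Cc1c(NN)nc(SCc2nc3ccccc3[nH]2)nc1-c1ccccc1` gives 2.68 nM, compound 2 `CNc1nc(SCc2nc3ccccc3[nH]2)nc(-c2ccccc2)c1C#N` gives 3.28 nM and compound 3 `CCNc1nc(SCc2nc3ccccc3[nH]2)nc(-c2ccccc2)c1C#N` gives 3.96 nM, so compound 3 stands level with the other two within the scatter. Compound 4 `N#Cc1c(Nc2nccs2)nc(SCc2nc3ccccc3[nH]2)nc1-c1ccccc1` carries 1,3-thiazol-2-yl in place of ethyl on a nitrogen on an aromatic ring. The nearest evidence is three small changes on that nitrogen: a 1.2-fold higher number from compound 1 to compound 2 (0.09 log units; within the scatter), a 1.5-fold higher number from compound 1 to compound 3 (0.17 log units; within the scatter) and a 1.2-fold higher number from compound 2 to compound 3 (0.08 log units; within the scatter), all within the scatter. None of them brings in a ring, so they guide only loosely. The step expected in this assay is a 1.0-fold higher number from compound 3 to compound 4 (0.00 log units; within the scatter), nothing beyond the scatter. For compound 4 the expected value is 4 nM, with an estimated range of 1.5 nM to 12 nM.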

Compound 4, half-maximal inhibitory concentration: 5.1 nM
Compound 4: the middle estimate sits 1.3-fold (0.11 log units) below what was measured, within the range that was stated.
By their numbers in this assay, from the lowest: compounds 1, 2, 3 and 4 (each within the scatter of the next).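

In this assay the steps are a 1.3-fold higher number from compound 3 to compound 4 (0.11 log units; within the scatter) and a 1.6-fold higher number from compound 2 to compound 4 (0.19 log units; within the scatter) and also a 1.9-fold higher number from compound 1 to compound 4 (0.28 log units; within the scatter), so the first ring placed on this nitrogen, 1,3-thiazol-2-yl, stays within the scatter of amino, methyl and ethyl alike. Nothing at hand bears on why this is so. The compounds shown leave open whether phenyl, pyridin-2-yl or acetyl on this nitrogen would also stay within the scatter. They also leave open what a change to the nitrile or to the phenyl group of the shared core would do.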